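Iodo for amino, starting from a limit

This account rests on a few compounds, and the source may have more. Where it says the series, first, only, none or still open, it means among the compounds named here.

In a functional assay on HL-60 cells (Homo sapiens) for antiproliferative activity (on this read-out higher numbers stand for weaker inhibition and lower numbers for stronger inhibition), compound 1 (`COC(=O)c1ccc(Oc2ccc(OC)cc2)c([N+](=O)[O-])c1`) gives > 20000 nM as a limit, not a number. Compound 2 (`COC(=O)c1ccc(Oc2ccc(OC)cc2)c(N)c1`) gives > 20000 nM as a limit too. Among the compounds with values here, the only measured step is a step that the two limits leave unreadable from compound 1 to compound 2 and so offers no size to carry forward, while the limit of > 20000 nM in this assay, at which 2 of the 2 values shown sit, is the whole of the evidence. Compound 3 (`COC(=O)c1ccc(Oc2ccc(OC)cc2)c(I)c1`) has iodo in place of amino on an aromatic carbon. Within the data shown here, with no sized step to lean on, only a modest move is expected, so an at least 1.3-fold lower number from compound 2 to compound 3 (0.12 log units; that floor lies within the scatter) is estimated in this assay as a shift toward stronger inhibition, if any. Compound 3 is expected at 15000 nM with a range from 3000 nM to 40000 nM as the estimate.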

Compound 3, half-maximal inhibitory concentration: > 20000 nM
Compound 3 gave a limit, no number; the forecaster's own chance of this, stated with the estimate: 55%; at least 1.3-fold (0.12 log units) between middle value and limit.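

Within the data shown here, no step among compound 1, compound 2 and compound 3 can be read, since each gives a limit, not a number: the limit of > 20000 nM in this assay, at which 3 of the 3 values shown sit. From the compounds shown here alone, whether nitro, amino and iodo differ at all in this assay stays open.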